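Methyl on the piperidine of compound 2

The source may report more compounds than this note shows. Statements on the series, on what has been measured and on what is new or still open speak of the compounds shown alone.

Measured compounds:
Compound 1, `COc1cc2c(Oc3ccc(NC(=O)c4nn(-c5ccccc5)c(=O)c5ccccc45)cc3F)ccnc2cc1OCCCN1CCCCC1`, 650 nM
Compound 2, `COc1cc2c(Oc3ccc(NC(=O)c4nn(-c5ccc(Br)cc5)c(=O)c5ccccc45)cc3F)ccnc2cc1OCCCN1CCCCC1`, 410 nM
Compound 3, `COc1ccc(-n2nc(C(=O)Nc3ccc(Oc4ccnc5cc(OCCCN6CCCCC6)c(OC)cc45)c(F)c3)c3ccccc3c2=O)cc1`, 840 nM

In a functional assay on NCI-H460 cells (Homo sapiens) for cytotoxicity, read by MTT assay, with a stated time of 72 h (on this read-out lower numbers stand for stronger inhibition and higher numbers for weaker inhibition), compound 2 gives the lowest of the three numbers. Its nearest neighbour is compound 1, and a 1.6-fold lower number from compound 1 to compound 2 (0.20 log units; within the scatter), while a 2.0-fold higher number from compound 2 to compound 3 (0.31 log units; beyond the scatter). The third pair shows a 1.3-fold higher number from compound 1 to compound 3 (0.11 log units; within the scatter).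

Compound 4, `COc1cc2c(Oc3ccc(NC(=O)c4nn(-c5ccc(Br)cc5)c(=O)c5ccccc45)cc3F)ccnc2cc1OCCCN1CCC(C)CC1`, differs from compound 2 by methyl in place of hydrogen on a saturated ring carbon; the change turns piperidin-1-yl into 4-methylpiperidin-1-yl on the chain at the far end of the shared core. Among the measured compounds shown here, none of the measured steps touches that ring: all three vary the substituent on the aromatic ring attached to the ring nitrogen of the core, and all stay small. Nothing measured here therefore bears on the methyl, and no step beyond the scatter is expected in this assay.

Compound 4 is accordingly expected to give 420 nM, with a range from 200 nM to 900 nM. That estimate means a 1.0-fold higher number from compound 2 to compound 4 (0.01 log units; within the scatter), which is expected to stay within the scatter.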

Compound 4, half-maximal inhibitory concentration: 350 nM
The estimate for compound 4 lay 1.2-fold (0.08 log units) above the measured number; the measured number falls inside the stated range.
By their numbers in this assay, from the lowest: compounds 4, 2, 1 and 3 (each within the scatter of the next, the first and the last beyond it).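

Among the compounds shown, only compound 4 alters the piperidin-1-yl group, so it gives the first reading on this end of the molecule. In this assay, methyl in place of hydrogen on a saturated ring carbon, three ring bonds from the ring nitrogen, gives a 1.2-fold lower number from compound 2 to compound 4 (0.07 log units; within the scatter). This position therefore accepts this single added methyl, as 4-methylpiperidin-1-yl, without a step that can be told from the scatter, and no measurement at hand offers an explanation for the result.

As far as these compounds go, it remains open whether a larger group on the same carbon, such as phenyl or hydroxyl, or a morpholine or piperazine in place of the piperidine, would stay as close to compound 2. The compounds shown also leave open whether the methyl would give a similar result with hydrogen or methoxy in place of the bromo group, as in compound 1 and compound 3.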